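From 3-fluorophenyl to 2-hydroxyphenyl in the series

The source may hold more compounds than are shown below. What is called first, only, known or untested is meant among the compounds shown, and "the series" means these compounds.

In a functional assay on HeLa cells (Homo sapiens) for inhibition, with a stated time of 72 h (a lower number here means a stronger inhibitor, a higher number a weaker inhibitor), compound 1 (`CC(C)(O)CNc1nc(NCc2ccc(-c3ccco3)cc2)c2ncn(C3CCCC3)c2n1`) gives 14800 nM, compound 3 (`NC1CCC(Nc2nc(NCc3ccc(-c4ccccc4O)cc3)c3ncn(C4CCCC4)c3n2)CC1`) gives 4180 nM and compound 2 (`NC1CCC(Nc2nc(NCc3ccc(-c4cccc(F)c4)nc3)c3ncn(C4CCCC4)c3n2)CC1`) gives 36 nM. Compound 2 has the lowest number of the three, beyond the scatter from both others. Compound 4 (`NC1CCC(Nc2nc(NCc3ccc(-c4ccccc4O)nc3)c3ncn(C4CCCC4)c3n2)CC1`) differs from compound 2 in one place: 2-hydroxyphenyl in place of 3-fluorophenyl on an aromatic carbon. For the measured compounds named here, no measured pair differs in one place only, so the expectation is loose. Compound 3 also carries 2-hydroxyphenyl and stands at 4180 nM, so a clear rise in this assay is expected. The estimated change is an 8.3-fold higher number from compound 2 to compound 4 (0.92 log units; beyond the scatter). For compound 4 the estimated value is 300 nM, with an expected range of 50 nM to 2500 nM.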

Compound 4, half-maximal inhibitory concentration: 16 nM
Estimate against measurement, compound 4: 19-fold (1.27 log units) above; measured number outside the range, below it.
By their numbers in this assay, from the lowest: compound 4; then compound 2; then compound 3; then compound 1.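

At this position, next to the ring nitrogen, this assay tolerates 2-hydroxyphenyl: replacing 3-fluorophenyl gives a 2.3-fold lower number from compound 2 to compound 4 (0.35 log units; beyond the scatter) and counts as a modest step. Compound 3 also carries 2-hydroxyphenyl and gives 4180 nM so that group alone does not set a high number in this series. No measurement at hand accounts for the step.

Still open, as far as these compounds go, is whether 2-methoxyphenyl or 2-aminophenyl at this position would hold the number of compound 4. Unsubstituted phenyl would show what the hydroxyl group itself contributes.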